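This account rests on a few compounds, and the source may have more. Where it says the series, first, only, none or still open, it means among the compounds named here.

Compound 1 `O=C1O/C(=C\Cn2cc(F)c(=O)[nH]c2=O)C(OCc2ccccc2)=C1OCc1ccccc1`: 5100 nM in an ADME assay on L1210/0 cells (Mus musculus) for cytotoxicity, with a stated time of 48 h; a higher number here means a weaker inhibitor, a lower number a stronger inhibitor.
Compound 2 `O=c1[nH]c(=O)n([C@H]2C[C@H](O)[C@@H](CO)O2)cc1C#CCCCO`: > 200000 nM in this assay, a limit of the assay, not a number.
Compound 3 `CO/N=C/C1CC(n2cnc3c(N)ncnc32)C(O)C1O`: > 200000 nM, likewise a limit.

Compound 2 thus stands at the limit of > 200000 nM in this assay, at which 2 of the 3 values shown sit; only compound 1 returns a number within range. Compound 4 `CCCCCCc1cn([C@H]2C[C@H](O)[C@@H](CO)O2)c(=O)[nH]c1=O` is the next candidate for this assay. Its change from compound 2: hexyl in place of 5-hydroxypent-1-yn-1-yl on an aromatic carbon. Within the data shown here, no step between measured compounds is available to read a size from, and compound 2 itself gives only a limit. The expectation is therefore a step of an at least 1.6-fold lower number from compound 2 to compound 4 (0.22 log units; that floor lies within the scatter) of no clear size, with compound 4 most likely remaining at or near the limit. Compound 4 is estimated at 120000 nM, within 15000 nM to 200000 nM.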

Compound 4, half-maximal inhibitory concentration: > 200000 nM
Compound 4 gave a limit, no number; the forecaster's own chance of this, stated with the estimate: 60%; middle value at least 1.6-fold (0.22 log units) away from the limit.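

Among these compounds, compound 2 and compound 4 both sit at a limit of this assay, not at a number, so no step between them can be read. The compounds shown leave open whether hexyl and 5-hydroxypent-1-yn-1-yl differ at all in this assay.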